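Chain length and amide ring in a benzofuran ketone series

A few compounds are considered here, and "the series" means these few. Any claim that something is new, unique, unknown or untested is made for them only; others in the source may bear on it.

The four compounds share one core, a butyl-substituted benzofuran carrying a ketone to a phenyl ring with an ether-linked amide. Compound 1 `CCCCc1oc2ccccc2c1C(=O)c1ccc(OCC(=O)N2CCCCC2)cc1` and compound 2 `CCCCc1oc2ccccc2c1C(=O)c1ccc(OCC(=O)N2CCOCC2)cc1` differ by morpholin-4-yl in place of piperidin-1-yl on a carbonyl carbon. Compound 3 `CCCCc1oc2ccccc2c1C(=O)c1ccc(OCCCC(=O)N2CCCCC2)cc1` differs from compound 1 by 2-((piperidin-1-yl)carbonyl)ethyl in place of (piperidin-1-yl)carbonyl on a saturated chain carbon bound to an oxygen on an aromatic ring. Compound 4 `CCCCc1oc2ccccc2c1C(=O)c1ccc(OCCCC(=O)N2CCOCC2)cc1` differs from compound 3 by morpholin-4-yl in place of piperidin-1-yl on a carbonyl carbon, the same change as that from compound 1 to compound 2, made at the same place.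

In a functional assay on MCF7 cells (Homo sapiens) for antiproliferative activity, read by MTT assay, with a stated time of 24 h (on this read-out higher numbers stand for weaker inhibition and lower numbers for stronger inhibition), compound 1 gives only a limit, > 50000 nM, and that limit is the limit of > 50000 nM in this assay, at which 1 of the 3 values shown sits. In this assay compound 2 gives 34000 nM. In this assay compound 3 gives 33000 nM. The step of an at least 1.4-fold lower number from compound 1 to compound 2 (0.16 log units; that floor lies within the scatter) and the step of an at least 1.5-fold lower number from compound 1 to compound 3 (0.18 log units; that floor lies within the scatter) are both floors set by the limit of compound 1, and the step of a 1.0-fold lower number from compound 2 to compound 3 (0.01 log units; within the scatter) shows compound 2 and compound 3 within the scatter of each other.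

For compound 4 he expects the same change to read much as it did before, a step of about a 1.2-fold lower number from compound 3 to compound 4 (0.07 log units; within the scatter), because the earlier step of an at least 1.4-fold lower number from compound 1 to compound 2 (0.16 log units; that floor lies within the scatter) from compound 1 to compound 2 only reached the floor set by the limit and gives no ground for a larger move. He therefore estimates compound 4 at 28000 nM in this assay, with a likely range from 12000 nM to 60000 nM.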

Compound 4, half-maximal inhibitory concentration: 41200 nM
Compound 4: middle estimate off by 1.5-fold (0.17 log units), on the low side, within the range that was stated.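

In this assay, a 1.2-fold higher number from compound 3 to compound 4 (0.10 log units; within the scatter) on the core of compound 3, and the change of chain with morpholin-4-yl held in place gives a 1.2-fold higher number from compound 2 to compound 4 (0.08 log units; within the scatter), so neither exchange moves the number beyond the usual scatter. Set beside the earlier exchange of piperidin-1-yl for morpholin-4-yl, the comparison stands as follows: the same change on two cores in this assay, an at least 1.4-fold lower number (0.16 log units; that floor lies within the scatter) from compound 1 to compound 2 and a 1.2-fold higher number (0.10 log units; within the scatter) from compound 3 to compound 4; the limit leaves it open whether they differ Compound 1 gives only a limit, an at least 1.2-fold lower number from compound 1 to compound 4 (0.08 log units; that floor lies within the scatter) is only a floor, and the four compounds therefore show neither that this change carries over unchanged from one core to the other nor that it reads differently on each: the limit of > 50000 nM in this assay, at which 1 of the 4 values shown sits.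

The compounds shown leave open how the same exchange would read on a longer chain than 2-((morpholin-4-yl)carbonyl)ethyl, and what a true number for compound 1 would make of the first step. They also leave open whether a piperazine ring, an open-chain amine or a carboxylic acid in place of these amides would give a number that stands clear of the scatter around those of compound 2, compound 3 and compound 4.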